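Replacing a Nitro Group with Bromine: Expected Potency

The source may hold more compounds than are shown below. What is called first, only, known or untested is meant among the compounds shown, and "the series" means these compounds.

Compound 1 `CN1CCN(c2nc3cc([N+](=O)[O-])ccc3o2)CC1` was tested in a functional assay on ileum (strain Hartley) for agonist activity at 5-hydroxytryptamine receptor 3A (Cavia porcellus) (on this read-out lower numbers stand for lower potency and higher numbers for higher potency (the scale is a negative logarithm)), where compound 1 gives 6.1. A second measured compound, compound 2 `COc1cc(C)cc2nc(N3CCN(C)CC3)oc12`, differs from compound 1 at more than one place, so its number can only be set side by side with that of compound 1; in this assay compound 2 gives 6.13. Going by the values given here, the two values lie within the usual scatter of repeated measurements, so nothing separates compound 1 from compound 2: compound 1 sits at the same level as the only other measured compound.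

The compound of interest is compound 3 `CN1CCN(c2nc3cc(Br)ccc3o2)CC1`. Its difference from compound 1 is bromo in place of nitro on an aromatic carbon. Among the compounds with values here, no step between two measured compounds that differ in one place exists in this set, so there is nothing from which the size of such a swap could be read. With that in mind, the change in compound 3 is expected to stay within the scatter, in no particular direction, as the step of a number 0.10 log units higher from compound 1 to compound 3 (within the scatter) expresses. Compound 3 is therefore estimated at 6.2 in this assay, with a range from 5.6 to 6.8.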

Compound 3, negative logarithm of the half-maximal effective concentration: 6.21
Compound 3: the middle estimate sits 0.01 log units below what was measured; the measured number falls inside the stated range.
By their numbers in this assay, from the lowest: compounds 1, 2 and 3 (each within the scatter of the next).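

Bromo in place of nitro on this aromatic carbon supplies the first step in the set between two compounds that differ in one place only, and it reads a number 0.11 log units higher from compound 1 to compound 3 (within the scatter) in this assay. The nitro group that leaves has 3 heavy atoms, 2 hydrogen-bond acceptors and a double bond, while the bromo that enters is a single heavy atom with no hydrogen-bond acceptors, yet the two compounds cannot be told apart on this read-out. This position can therefore carry either of these two quite different groups with the same level of agonist potency in the guinea-pig ileum, although no measurement shown here accounts for that outcome.

With only this one swap shown, it remains open whether the level would also hold with a very different group on the same carbon, such as an amine, a carboxylic acid or a longer chain. As far as these compounds go, it is equally open whether the same swap would give a similar step on another aromatic carbon of the core of compound 1, or on a core carrying further substituents.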